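Adding 2-hydroxyethyl to the amino nitrogen of compound 2

The compounds below may be only part of what the source reports. "The series", "measured", "known", "first", "only" and "open" are said of these compounds alone.

In a physicochemical assay for solubility, at pH 7.4 (on this read-out higher numbers stand for higher solubility and lower numbers for lower solubility), compound 1 (`Cc1cc(C)n(-c2nc(C(F)(F)F)cc(=O)[nH]2)n1`) gives 200000 nM and compound 2 (`Cc1cc(N)n(-c2nc(C(F)(F)F)cc(=O)[nH]2)n1`) gives 200000 nM on the same scale, so compound 2 stands level with compound 1 at the digits shown. The next structure is compound 3 (`Cc1cc(NCCO)n(-c2nc(C(F)(F)F)cc(=O)[nH]2)n1`). It carries 2-hydroxyethyl in place of hydrogen on a nitrogen on an aromatic ring, which also reads as amino to (2-hydroxyethyl)amino (2-hydroxyethyl in place of hydrogen on a nitrogen on an aromatic ring).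

For the measured compounds named here, only one measured step bears on this change. Amino in place of methyl on an aromatic carbon gave no change at the digits printed from compound 1 to compound 2 (within the scatter) and so stayed within the scatter. Going by the values given here, that step is only indirect evidence, as no measured compound carries 2-hydroxyethyl. With so little to go on, no step beyond the scatter is expected in this assay and neither direction is favoured. The expected size is no change at the digits printed from compound 2 to compound 3 (within the scatter) on this estimate. Compound 3 is therefore estimated at 200000 nM (range 100000 nM to 300000 nM).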

Compound 3, solubility: 200000 nM
For compound 3 middle estimate and measured number coincide at the digits printed; the measured number falls inside the stated range.
By their numbers in this assay, from the lowest: compounds 1, 2 and 3 (each within the scatter of the next).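

In this assay, for the compounds shown here, 2-hydroxyethyl in place of hydrogen on the amino nitrogen gives no change at the digits printed from compound 2 to compound 3 (within the scatter), so this nitrogen now has a measured substituent of 3 heavy atoms and no ring, where the earlier compounds offered only the unsubstituted amino group. Taken against the methyl group on the aromatic carbon, (2-hydroxyethyl)amino gives no change at the digits printed from compound 1 to compound 3 (within the scatter), which extends the earlier reading from amino to a substituted amino group at the same place, with all three values level at the digits printed. Nothing measured on hand accounts for this flat reading.

Still open, as far as these compounds go, is whether the reading stays level with other groups on this nitrogen, such as a longer chain, a carboxylic acid or a second 2-hydroxyethyl on the same nitrogen. Also open, from the compounds shown here alone, is how far this holds with the rest of the core changed, for example with a nitrile in place of trifluoromethyl, since all three compounds carry trifluoromethyl and so say nothing about whether the level reading depends on that group.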